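A few compounds are considered here, and "the series" means these few. Any claim that something is new, unique, unknown or untested is made for them only; others in the source may bear on it.

Values in a functional assay on MKN-45 cells (Homo sapiens) for antiproliferative activity, read by CellTiter-Glo, with a stated time of 3 days; a lower number here means a stronger inhibitor, a higher number a weaker inhibitor:
- compound 1 `CC(Oc1c(N)ncc2c(-c3cnn(C4CCNCC4)c3)coc12)c1cc(F)ccc1Cl`: 6400 nM
- compound 2 `CC(Oc1c(N)ncc2c(-c3cnn(C4CCNCC4)c3)coc12)c1c(Br)ccc(F)c1Cl`: 510 nM
- compound 3 `C[C@@H](Oc1c(N)ncc2c(-c3cn[nH]c3)coc12)c1c(Cl)ccc(F)c1Cl`: 3300 nM

Compound 3 at 3300 nM lies within the scatter of compound 1 at 6400 nM. Compound 2 at 510 nM has a number lower than compound 3, beyond the scatter.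

The next change leads to compound 4 `C[C@@H](Oc1c(N)ncc2c(C3=CCN(C(=O)N(C)C)CC3)coc12)c1c(Cl)ccc(F)c1Cl` and replaces 1H-pyrazol-4-yl: a group of 11 heavy atoms (8 carbon, 2 nitrogen, 1 oxygen; one six-membered non-aromatic ring with 1 hetero atom) in place of a group of 5 heavy atoms (3 carbon, 2 nitrogen; one five-membered aromatic ring with 2 hetero atoms), on an aromatic carbon. It sits two ring bonds from the ring oxygen.

Among the compounds with values here, the only measured step is a 13-fold lower number from compound 1 to compound 2 (1.10 log units; beyond the scatter). It is large, but it lies on a saturated chain carbon bound to an oxygen on an aromatic ring, not on the aromatic carbon changed here. Within the data shown here, no measured step covers this place, so the series gives no direct size for the change, and the direction remains uncertain.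

In this assay the expected step is a 1.7-fold lower number from compound 3 to compound 4 (0.22 log units; within the scatter), which is estimated to stay within the scatter.

Compound 4 is estimated at 2000 nM, with an expected range from 400 nM to 8000 nM.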

Compound 4, half-maximal inhibitory concentration: 510 nM
Estimate against measurement, compound 4: 3.9-fold (0.59 log units) above, within the range that was stated.
By their numbers in this assay, from the lowest: compounds 2 and 4 (each within the scatter of the next); then compounds 3 and 1 (each within the scatter of the next).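

In this assay, the aromatic carbon two ring bonds from the ring oxygen responds to a change of group, with a 6.5-fold lower number from compound 3 to compound 4 (0.81 log units; beyond the scatter). The 1H-pyrazol-4-yl is therefore not needed at this place for a number of this size: a group of 11 heavy atoms built on a six-membered non-aromatic ring, with 0 hydrogen-bond donors, is tolerated and gives the lower number. Nothing measured on these compounds bears on why the number falls.

With ring, size and donor count all changing in one step, the compounds shown do not separate the contribution of the ring from that of the group on its nitrogen. On these data alone, whether a simple primary amine or a carboxylic acid on the same ring would keep the lower number remains open.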